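A few compounds are considered here, and "the series" means these few. Any claim that something is new, unique, unknown or untested is made for them only; others in the source may bear on it.

Measured compounds:
- compound 1 `CC#CC(CC(=O)O)c1ccc(OCc2ccc3nc(-c4ccccc4C)cn3c2)cc1`: 389 nM
- compound 2 `CC#CC(CC(=O)O)c1ccc(OCc2ccc3nc(-c4ccccc4)cn3c2)cc1`: 979 nM
- compound 3 `CC#CC(CC(=O)O)c1ccc(OCc2ccc3nc(-c4ccc(F)cc4)cn3c2)cc1`: 623 nM

In an assay on isolated protein for agonist activity at Free fatty acid receptor 1 (Homo sapiens) (a higher number here means that more compound is needed for the effect, a lower number that less compound is needed), compound 3 gives 623 nM, the second highest of the three numbers; its gaps to compound 2 and to compound 1 both lie within the scatter, so no order among the three is settled.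

Compound 4 `CC#CC(CC(=O)O)c1ccc(OCc2ccc3nc(-c4cccc(C)c4)cn3c2)cc1` differs from compound 3 by 3-methylphenyl in place of 4-fluorophenyl on an aromatic carbon. Relevant steps: the methyl removal a 2.5-fold higher number from compound 1 to compound 2 (0.40 log units; beyond the scatter) was modest and beyond the scatter; a 1.6-fold lower number from compound 2 to compound 3 (0.20 log units; within the scatter) and a 1.6-fold higher number from compound 1 to compound 3 (0.20 log units; within the scatter) stayed within it. A 3-methylphenyl is not the 2-methylphenyl of compound 1, so the gain seen there is not assumed to carry over; a step of a 1.2-fold lower number from compound 3 to compound 4 (0.10 log units; within the scatter) is expected, toward slightly lower numbers at most. Compound 4 is estimated at 500 nM, range 200 nM to 1300 nM.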

Compound 4, half-maximal effective concentration: 1050 nM
Estimate against measurement, compound 4: 2.1-fold (0.32 log units) below, within the range that was stated.
By their numbers in this assay, from the lowest: compounds 1, 3, 2 and 4 (each within the scatter of the next, the first and the last beyond it).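

In this assay the 3-methylphenyl does not repeat the result of the 2-methylphenyl, since a 2.7-fold higher number from compound 1 to compound 4 (0.43 log units; beyond the scatter) is beyond the scatter. Methyl on the phenyl at this new place gives no readable change, with a 1.1-fold higher number from compound 2 to compound 4 (0.03 log units; within the scatter) within the scatter, and a 1.7-fold higher number from compound 3 to compound 4 (0.23 log units; within the scatter) also leaves 3-methylphenyl and 4-fluorophenyl unseparated. Nothing available explains this dependence on where the methyl sits.

Open, going by these compounds, is whether an ethyl, methoxy or amine in place of the methyl of compound 1 would hold that lower number. Also open, on these data alone, is whether any group at the place of the methyl of compound 4 would separate from compound 2 beyond the scatter.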